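This account rests on a few compounds, and the source may have more. Where it says the series, first, only, none or still open, it means among the compounds named here.

Compound 1, `CC(C(=O)NCc1ccc(C(F)(F)F)nc1-c1ccc(Cl)cc1)c1ccc(NS(C)(=O)=O)c(F)c1`: in an assay on CHO cells for antagonist activity at transient receptor potential cation channel subfamily V member 1 (Homo sapiens), read by FLIPR (a lower number here means a stronger inhibitor, a higher number a weaker inhibitor), compound 1 gives 0.7 nM.
Compound 2, `COc1ccc(-c2nc(C(F)(F)F)ccc2CNC(=O)C(C)c2ccc(NS(C)(=O)=O)c(F)c2)cc1F`: in this assay compound 2 gives 4.2 nM.
Compound 3, `CC(C(=O)NCc1ccc(C(F)(F)F)nc1-c1ccc2cc[nH]c2c1)c1ccc(NS(C)(=O)=O)c(F)c1`: in this assay compound 3 gives 20.3 nM.

Among these three, compound 3 carries the highest number. The gaps to its neighbours are a 4.8-fold higher number from compound 2 to compound 3 (0.68 log units; beyond the scatter) and a 29-fold higher number from compound 1 to compound 3 (1.46 log units; beyond the scatter), and between the other two lies a 6.0-fold higher number from compound 1 to compound 2 (0.78 log units; beyond the scatter). All three steps exchange one aromatic group at the same place of the shared core and all lie beyond the scatter, so this position is where the series moves.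

Compound 4, `CC(C(=O)NCc1ccc(C(F)(F)F)nc1C#Cc1ccccc1)c1ccc(NS(C)(=O)=O)c(F)c1`, continues from compound 3 with 2-phenylethynyl in place of 1H-indol-6-yl on an aromatic carbon. Within the data shown here, no measured step puts a group joined through a triple bond at this position, so the three aryl-for-aryl steps bear on it only indirectly: they show that exchanges here range from modest to large, and that the indolyl of compound 3 gave the weakest result of the three. Given that compound 3 sits at the top of the range, a return toward the numbers of compounds 1 and 2 is plausible but not established, and the expected step is a 2.0-fold lower number from compound 3 to compound 4 (0.31 log units; beyond the scatter). Compound 4 is therefore estimated at 10 nM, within 1.5 nM to 80 nM.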

Compound 4, inhibition constant: 0.8 nM
Compound 4: the middle estimate sits 13-fold (1.10 log units) above what was measured, outside the stated range (below it).
By their numbers in this assay, from the lowest: compounds 1 and 4 (each within the scatter of the next); then compound 2; then compound 3.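

The result shows that the aromatic group at this place, on the aromatic carbon next to the ring nitrogen, need not be attached directly to the shared core: with one triple bond outside aromatic rings and a single six-membered aromatic ring of carbon only, 2-phenylethynyl gives a 25-fold lower number from compound 3 to compound 4 (1.40 log units; beyond the scatter) in this assay. It also stands level with the best aryl group seen so far, a 1.1-fold higher number from compound 1 to compound 4 (0.06 log units; within the scatter), and it outperforms 3-fluoro-4-methoxyphenyl, a 5.3-fold lower number from compound 2 to compound 4 (0.72 log units; beyond the scatter), so the earlier aryl-for-aryl exchanges did not mark the limit of what this place accepts. No measurement among the data shown accounts for these differences.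

The compounds shown leave open how much of the result of compound 4 depends on its terminal phenyl ring, since no compound here ends the triple bond in a small group such as methyl, in a hydroxymethyl group or in a basic amine. They also leave open whether a chlorine on that phenyl ring, the atom carried by the 4-chlorophenyl of compound 1, would change the number, or whether a longer chain between the triple bond and the ring would be accepted.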